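The compounds below may be only part of what the source reports. "The series", "measured", "known", "first", "only" and "open" are said of these compounds alone.

Measured in a functional assay on MCF7 cells (Homo sapiens) for cytotoxicity, read by MTT assay, with a stated time of 72 h; on this read-out lower numbers stand for stronger inhibition and higher numbers for weaker inhibition:
- compound 1 `CN(C)CCCCCn1c2c(c3ccccc31)C(=O)c1c[n+]([O-])c3ccccc3c1C2=O`: 200 nM
- compound 2 `O=C1c2c[n+]([O-])c3ccccc3c2C(=O)c2c1c1ccccc1n2Cc1cn(C[C@H](O)CO)nn1`: > 1000 nM
- compound 3 `O=C1c2c[n+]([O-])c3ccccc3c2C(=O)c2c1c1ccccc1n2CCCCN1CCNCC1`: 12000 nM

Compound 2 has no number in this assay, only a limit of the assay, > 1000 nM.

Compound 4 `CC1(C)O[C@@H](CO)[C@H](Cn2cc(Cn3c4c(c5ccccc53)C(=O)c3c[n+]([O-])c5ccccc5c3C4=O)nn2)O1` differs from compound 2 in one part of the side chain: 5-(hydroxymethyl)-2,2-dimethyl-1,3-dioxolan-4-yl in place of 1,2-dihydroxyethyl on a saturated chain carbon bound to an aromatic nitrogen. Cut one bond further out, the same change reads 2,3-dihydroxypropyl to (5-(hydroxymethyl)-2,2-dimethyl-1,3-dioxolan-4-yl)methyl.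

Within the data shown here, no measured step makes this exchange, so the evidence is indirect. Two side-chain exchanges on the shared core bear on it: an at least 5.0-fold higher number from compound 1 to compound 2 (0.69 log units; beyond the scatter) and a 60-fold higher number from compound 1 to compound 3 (1.78 log units; beyond the scatter). Both lie beyond the scatter, which shows that among these three compounds a change in this chain can move the read-out considerably. As far as these compounds go, a third comparison stays open: a step that the limit leaves unreadable from compound 2 to compound 3.

Compound 4 keeps the rest of the chain of compound 2, so it is expected to stay close to compound 2 rather than approach compound 1 at 200 nM. In this assay, a modest rise in the number is therefore expected, well short of the large 60-fold higher number from compound 1 to compound 3 (1.78 log units; beyond the scatter). The expected change is a step that the limit leaves unreadable from compound 2 to compound 4. For compound 4 the estimate is 2500 nM, with an expected range of 600 nM to 10000 nM.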

Compound 4, half-maximal inhibitory concentration: 690 nM
Estimate against measurement, compound 4: 3.6-fold (0.56 log units) above; measured number inside the range.
By their numbers in this assay, from the lowest: compound 1; then compound 4; then compound 3.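

In this assay, placing 5-(hydroxymethyl)-2,2-dimethyl-1,3-dioxolan-4-yl in place of 1,2-dihydroxyethyl on a saturated chain carbon bound to an aromatic nitrogen gives compound 4 a measured number, which compound 2 lacks, so this side chain now has one readable value on the shared core. The exchange, which adds a five-membered non-aromatic ring and a second defined stereocentre, gives an at least 1.4-fold lower number from compound 2 to compound 4 (0.16 log units; that floor lies within the scatter), so the lower number of compound 4 is a real reading, but the floor of the step alone does not establish a change beyond the scatter. Compound 2 carries only a limit of the assay, and the true size of the step stays unfixed: the limit of > 1000 nM in this assay, at which 1 of the 4 values shown sits.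

What the compounds shown leave open is how far compound 2 actually lies from compound 4, and thus whether the ring-bearing chain differs from the free 2,3-dihydroxypropyl chain by more than the scatter. Also open, as far as these compounds go, is how the number would move if a carboxylic acid or a methyl ether took the place of the hydroxymethyl on the 1,3-dioxolane ring, or if a longer chain carried that ring.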